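The compounds below may be only part of what the source reports. "The series", "measured", "known", "first", "only" and "open" are said of these compounds alone.

The study concerns analgesic candidates tested in a functional assay on the whole organism (Tail, strain ICR) with Mus musculus as the target, in the tail flick test, with a stated time of 30 min, at a dose of 25 umol/kg by the oral route; a higher number here means a stronger effect of the compound at the dose given, a lower number a weaker effect. Compound 1 `CC[C@H](C)[C@H](NC(=O)CN(c1nc(Cl)nc2[nH]cnc12)C1CC1)C(=O)O` gives 30.3% there, and compound 2 `C[C@@H](O)[C@H](NC(=O)CN(c1ncnc2c1ncn2C1CCCCO1)C1CC1)C(=O)OCc1ccccc1` gives 23.6% in this assay; these two numbers lie within the usual scatter of each other, so neither compound stands apart from the other. Compound 3 `O=C(CN(c1ncnc2c1ncn2C1CCCCO1)C1CC1)N[C@@H](CC(=O)OCc1ccccc1)C(=O)OCc1ccccc1` has not yet been measured. It differs from compound 2 in one place: (benzyloxycarbonyl)methyl in place of 1-hydroxyethyl on a saturated chain carbon bound to an amide-type nitrogen and a carbonyl carbon. Among the measured compounds shown here, no step between measured compounds exists to anchor the size of such a change, so no shift beyond the scatter is expected in either direction. Compound 3 is estimated to give 25% in this assay, with a range from 8% to 45%, which corresponds to an expected step of a number 1.4 percentage points higher from compound 2 to compound 3 (within the scatter).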

Compound 3, a percentage reported as activity, at one dose (the size of the read-out at that dose, not a potency): 31.8%
For compound 3 the middle estimate is 6.8 percentage points below the measured one, within the range that was stated.
By their numbers in this assay, from the lowest: compounds 2, 1 and 3 (each within the scatter of the next).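

In this assay, placing (benzyloxycarbonyl)methyl in place of 1-hydroxyethyl on a saturated chain carbon bound to an amide-type nitrogen and a carbonyl carbon gives a number 8.2 percentage points higher from compound 2 to compound 3 (within the scatter). This first step at the position shows that a much larger group, with a six-membered aromatic ring and no hydrogen-bond donor, leaves the read-out within the scatter. Nothing measured here explains this result.

As far as these compounds go, whether any group at this place can move the number beyond the scatter remains open. A primary amine or a longer alkyl chain there would test this.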